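Taking the Methoxy Off: Expected Hemolysis for Compound 4

A few compounds are considered here, and "the series" means these few. Any claim that something is new, unique, unknown or untested is made for them only; others in the source may bear on it.

Three compounds of one shared core have been measured in an ADME assay on cells (Erythrocyte, Homo sapiens) for activation, read by hemolysis, with a stated time of 30 min, tested at 2.5 mM; on this read-out lower numbers stand for a weaker effect and higher numbers for a stronger effect at the one concentration tested:

Compound 1, `N=C(N)c1ccc(-c2ccc(-c3ccc(F)cc3)o2)o1`, gives 17.6%.
Compound 2, `N=C(N)c1ccc(-c2ccc(-c3ccc(Cl)cc3)o2)o1`, gives 41.3%.
Compound 3, `COc1ccc(-c2ccc(-c3ccc(C(=N)N)o3)o2)cc1`, gives 8.1%.

Compound 3 stands lowest of the three numbers. Its nearest neighbour is compound 1, reached by the step of a number 9.5 percentage points lower from compound 1 to compound 3 (within the scatter), and its furthest is compound 2, reached by the step of a number 33.2 percentage points lower from compound 2 to compound 3 (beyond the scatter).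

Compound 4, `N=C(N)c1ccc(-c2ccc(-c3ccccc3)o2)o1`, differs from compound 3 in one place: hydrogen in place of methoxy on an aromatic carbon. The substituent sits on a six-membered aromatic ring of carbon only, para to a large group.

For the measured compounds named here, two measured steps bear on this change, both ending at the methoxy of compound 3: a number 9.5 percentage points lower from compound 1 to compound 3 (within the scatter) and a number 33.2 percentage points lower from compound 2 to compound 3 (beyond the scatter). Undoing a methoxy has thus once given no step beyond the scatter and once a large rise. Going by the values given here, no measured compound carries hydrogen at this place, so the expectation leans on compound 1, whose step a number 9.5 percentage points lower from compound 1 to compound 3 (within the scatter) was the smaller one. A modest rise at most is expected, a number 6.9 percentage points higher from compound 3 to compound 4 (within the scatter). Compound 4 is estimated at 15%, within a range from 3% to 35%.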

Compound 4, a percentage reported as activity, at one concentration (the size of the read-out at that concentration, not a potency): 7%
Compound 4: middle estimate off by 8 percentage points, on the high side; the measured number falls inside the stated range.
By their numbers in this assay, from the lowest: compounds 4, 3 and 1 (each within the scatter of the next, the first and the last beyond it); then compound 2.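

In this assay hydrogen now gives this position a plain reference point, and the step of a number 1.1 percentage points lower from compound 3 to compound 4 (within the scatter) shows that taking off the methoxy brings no separation beyond the scatter. Against that reference the two halogens stand apart, with the step of a number 10.6 percentage points lower from compound 1 to compound 4 (beyond the scatter) being modest and the step of a number 34.3 percentage points lower from compound 2 to compound 4 (beyond the scatter) being large, so chloro and, to a smaller degree, fluoro go with more hemolysis than hydrogen, while methoxy does not. Nothing measured here explains why these groups differ.

From the compounds shown here alone, whether this holds for halogens more widely stays open, and bromo or iodo at the same place would test it. Going by these compounds, how an amine, a carboxylic acid or a longer chain such as ethoxy would read there is equally open.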